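This account rests on a few compounds, and the source may have more. Where it says the series, first, only, none or still open, it means among the compounds named here.

Measured compounds:
compound 1, `COc1cc(-c2cc(/C=C/C(=O)c3ccc(Cl)c(Cl)c3)[nH]n2)cc(OC)c1OC`: 105%
compound 2, `COc1ccc(C(=O)/C=C/c2cc(-c3cc(OC)c(OC)c(OC)c3)n[nH]2)cc1`: 102%

In a functional assay on NCI-H460 cells (Homo sapiens) for cytotoxicity, read by sulforhodamine B assay, with a stated time of 48 h, tested at 0.1 uM (on this read-out higher numbers stand for a weaker effect at the one concentration tested and lower numbers for a stronger effect), compound 1 gives 105% and compound 2 gives 102%; the two numbers sit within the scatter of each other, and compound 2 has no other neighbour to be set against. Going by the values given here, the only measured step, a number 3 percentage points lower from compound 1 to compound 2 (within the scatter), swapped the group on the carbonyl carbon without effect beyond the scatter. Compound 3, `COc1cc(-c2cc(/C=C/C(=O)c3ccc(F)c(F)c3)[nH]n2)cc(OC)c1OC`, differs from compound 2 by 3,4-difluorophenyl in place of 4-methoxyphenyl on a carbonyl carbon, a change at the same carbonyl carbon. Since the step to compound 2 from compound 1 was flat, the step of a number 1 percentage points higher from compound 2 to compound 3 (within the scatter) is expected to stay within the scatter as well. For compound 3 the estimate is 103%, with a range from 91% to 115%.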

Compound 3, a percentage reported as activity, at one concentration (the size of the read-out at that concentration, not a potency): 102%
Compound 3: middle estimate off by 1 percentage points, on the high side; the measured number falls inside the stated range.
By their numbers in this assay, from the lowest: compounds 2, 3 and 1 (each within the scatter of the next).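

In this assay the 3,4-difluorophenyl group on the carbonyl carbon gives no change at the digits printed from compound 2 to compound 3 (within the scatter) and a number 3 percentage points lower from compound 1 to compound 3 (within the scatter). A third group at this carbon, with fluorine on its ring and no hydrogen-bond acceptor, thus joins the 4-methoxyphenyl and 3,4-dichlorophenyl groups within the scatter, so this read-out at its one concentration does not separate the three. No supporting information bears on this flat result. On these data alone, whether a carboxylic acid, an amine or a short alkyl chain on this carbonyl carbon would move the number remains open, as does whether the three compounds would separate at another concentration.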